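Piperidin-1-yl in place of dimethylamino on the chain

A few compounds are considered here, and "the series" means these few. Any claim that something is new, unique, unknown or untested is made for them only; others in the source may bear on it.

Two compounds on a shared core open the series: compound 1 (`CN(C)CCn1cccc1/C=N/NC(=O)Nc1ccc(Oc2ccnc3[nH]ccc23)cc1`), with a 2-(dimethylamino)ethyl group, and compound 2 (`CN(C)CCCn1cccc1/C=N/NC(=O)Nc1ccc(Oc2ccnc3[nH]ccc23)cc1`), with a 3-(dimethylamino)propyl group. In a functional assay on MCF7 cells (Homo sapiens) for antiproliferative activity, read by MTT assay, with a stated time of 72 h (a lower number here means a stronger inhibitor, a higher number a weaker inhibitor), compound 1 stands as "not determined" (no result reported) and offers no comparison. In this assay, within the data shown here, compound 2 gives 9140 nM as the only number available, so it cannot yet be ranked against anything and serves only as a reference point.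

Compound 3 (`O=C(N/N=C/c1cccn1CCCN1CCCCC1)Nc1ccc(Oc2ccnc3[nH]ccc23)cc1`) differs from compound 2 in one place: piperidin-1-yl in place of dimethylamino on a saturated chain carbon, three bonds along the chain from an aromatic nitrogen turns the 3-(dimethylamino)propyl group into 3-(piperidin-1-yl)propyl. Among the measured compounds shown here, no measured step covers this change, so the expectation is loose. It rests on compound 2 alone, at 9140 nM in the absence of any second anchor. No shift beyond the usual scatter is expected in this assay, with a slight lean towards a stronger inhibitor at most. The expected size is a 1.2-fold lower number from compound 2 to compound 3 (0.09 log units; within the scatter) as an estimate only. For compound 3 the estimated value is 7500 nM with an expected range of 2500 nM to 20000 nM for the coming measurement.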

Compound 3, half-maximal inhibitory concentration: 4690 nM
Beside the measured number, compound 3's estimate is 1.6-fold (0.20 log units) above it; the measured number falls inside the stated range.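

In this assay, among these compounds, the first readable step at this position is a 1.9-fold lower number from compound 2 to compound 3 (0.29 log units; within the scatter), for piperidin-1-yl in place of dimethylamino on a saturated chain carbon, three bonds along the chain from an aromatic nitrogen. For this pair, the open dimethylamino end and the six-membered non-aromatic ring of piperidin-1-yl therefore cannot be told apart in the read-out, so compound 2 no longer stands alone and this chain end accepts a ring without a shift beyond the scatter, though one pair supports no wider pattern. Nothing measured here speaks to a cause for this result.

With compound 1 at "not determined" (no result reported), the compounds shown give no reading of the 2-(dimethylamino)ethyl chain against the 3-(dimethylamino)propyl chain, and the same holds for 2-(piperidin-1-yl)ethyl, so the effect of chain length stays unknown. Also open, as far as these compounds go, is whether a morpholin-4-yl or 4-methylpiperazin-1-yl end, with a second hetero atom in the ring, or a carboxylic acid at the end of the propyl chain, would move the number beyond the scatter in this assay.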